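This account rests on a few compounds, and the source may have more. Where it says the series, first, only, none or still open, it means among the compounds named here.

Measured compounds:
compound 1 `CNc1nc(NCCCN(C)C)c2sc(-c3ccc(C(F)(F)F)cc3)cc2n1`: 177 ug/mL
compound 2 `CNc1nc(N)c2sc(-c3ccc(C(F)(F)F)cc3)cc2n1`: 3.1 ug/mL
compound 3 `CNc1nc(NC(C)(C)C)c2sc(-c3ccc(C(F)(F)F)cc3)cc2n1`: < 1.6 ug/mL

In a physicochemical assay for solubility, in phosphate buffer, at pH 6.5 (a lower number here means a less soluble compound, a higher number a more soluble compound), compound 1 gives 177 ug/mL, the highest of the numbers shown. Compound 2 gives 3.1 ug/mL in this assay. For compound 3 the assay reports only a limit, < 1.6 ug/mL, which is the limit of < 1.6 ug/mL in this assay, at which 1 of the 3 values shown sits. Two steps are large: a 57-fold lower number from compound 1 to compound 2 (1.76 log units; beyond the scatter), and an at least 110-fold lower number from compound 1 to compound 3 (2.04 log units; beyond the scatter). The third step is an at least 1.9-fold lower number from compound 2 to compound 3 (0.28 log units; that floor lies within the scatter).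

Compound 4 `CN(C)CCCNc1nc(N)nc2cc(-c3ccc(C(F)(F)F)cc3)sc12` differs from compound 1 by hydrogen in place of methyl on a nitrogen on an aromatic ring; cut one bond further out, methylamino becomes amino. The 3-(dimethylamino)propyl group of compound 1 is kept. Within the data shown here, none of the measured steps touches this nitrogen: the two large steps away from compound 1 remove the 3-(dimethylamino)propyl group at the other nitrogen, and the step from compound 2 to compound 3 adds tert-butyl there. Among the measured compounds shown here, no measured step therefore bears directly on the change to compound 4, and a step no larger than the scatter is expected, in no set direction. Compound 4 is expected to give 150 ug/mL in this assay, with a range from 60 ug/mL to 400 ug/mL, which means an expected step of a 1.2-fold lower number from compound 1 to compound 4 (0.07 log units; within the scatter).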

Compound 4, solubility: 148 ug/mL
Compound 4: middle estimate off by 1.0-fold (0.01 log units), on the high side; the measured number falls inside the stated range.
By their numbers in this assay, from the lowest: compound 2; then compounds 4 and 1 (each within the scatter of the next). At a limit, below all of these: compound 3.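

Among these compounds, the methylamino nitrogen, untouched by the earlier steps, now has a reading of its own: in this assay, with the 3-(dimethylamino)propyl group kept, hydrogen in place of methyl on this nitrogen gives a 1.2-fold lower number from compound 1 to compound 4 (0.08 log units; within the scatter). The other nitrogen carries a large step, a 57-fold lower number from compound 1 to compound 2 (1.76 log units; beyond the scatter), whereas compound 1 and compound 4 cannot be told apart, so in this pair the high number does not rest on the methyl. Nothing shown gives a cause for the step on the methylamino nitrogen.

Going by these compounds, this reading rests on a single pair with the 3-(dimethylamino)propyl group in place, so whether methylamino and amino also match when hydrogen or tert-butyl sits on the other nitrogen stays open. Larger groups at the methylamino position, such as ethylamino, dimethylamino or a morpholine, and a shorter or longer aminoalkyl chain at the other nitrogen lie outside the compounds shown, which leaves open how far either position can be varied in this assay.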